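The source may report more compounds than this note shows. Statements on the series, on what has been measured and on what is new or still open speak of the compounds shown alone.

Measured in an ADME assay on RD cells (Homo sapiens) for cytotoxicity; a higher number here means that more compound is tolerated, a lower number that less compound is tolerated:
Compound 1, `CCN(CC)C(=S)N/N=C1\C(=O)Nc2ccccc21`, gives a limit of > 25000 nM.
Compound 2, `CCCNC(=S)N/N=C1\C(=O)Nc2ccccc21`, gives a limit of > 25000 nM.
Compound 3, `CCNC(=S)N/N=C1\C(=O)Nc2ccccc21`, gives a limit of > 25000 nM.

Compound 3 thus stands at the limit of > 25000 nM in this assay, at which 3 of the 3 values shown sit. The unmeasured compound 4, `O=C1Nc2ccccc2/C1=N/NC(=S)N1CCCC1`, differs from compound 3 by pyrrolidin-1-yl in place of ethylamino on a thiocarbonyl carbon. All measured steps run from one limit to another: a step that the two limits leave unreadable from compound 1 to compound 2, a step that the two limits leave unreadable from compound 1 to compound 3 and a step that the two limits leave unreadable from compound 2 to compound 3. None of them has a readable size, so they give no direction for the new change. No step beyond the scatter is expected, a step that the limit leaves unreadable from compound 3 to compound 4. Compound 4 is estimated at 30000 nM, with a range from 15000 nM to 80000 nM, most likely again reported only as a limit.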

Compound 4, half-maximal cytotoxic concentration: > 25000 nM
Compound 4 ended at the assay's limit; the forecaster's own chance of this, stated with the estimate: 80%; the middle value does not contradict the limit.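

Compound 4 sits at the same limit as compound 1, compound 2 and compound 3, so no step among these compounds can be read: the limit of > 25000 nM in this assay, at which 4 of the 4 values shown sit.

The compounds shown leave open at what concentration any of them becomes toxic to the cells, and whether the group on the thiocarbonyl carbon changes that concentration.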